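Swapping a Hydroxyphenyl for Thiophene on the Shared Core

A few compounds are considered here, and "the series" means these few. Any claim that something is new, unique, unknown or untested is made for them only; others in the source may bear on it.

Compound 1 `Cc1ccc(-c2ccccc2OC(C)C2=NCCN2)cc1` and compound 2 `CC(Oc1ccccc1-c1ccccc1O)C1=NCCN1` share one core and differ by a 2-hydroxyphenyl in place of 4-methylphenyl on an aromatic carbon. In a functional assay on CHO cells for agonist activity at Alpha-2B adrenergic receptor (Homo sapiens) (a lower number here means a smaller maximal response, a higher number a larger maximal response), compound 1 gives < 0.3, which is a limit of the assay rather than a number. Compound 2 gives < 0.3, also a limit. The step that the two limits leave unreadable from compound 1 to compound 2 cannot be read because both values sit at the limit of < 0.3 in this assay, at which 2 of the 2 values shown sit. Compound 3 `CC(Oc1ccccc1-c1cccs1)C1=NCCN1` carries thiophen-2-yl in place of 2-hydroxyphenyl on an aromatic carbon. Among the measured compounds shown here, no measured step gives a readable size, so no direction beyond the scatter is expected. Compound 3 is expected to give 0.3, between 0.1 and 0.6. The expected step of a number no lower from compound 2 to compound 3 (the limit leaves the size open) is accordingly judged small.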

Compound 3, intrinsic activity: the largest response reached, as a fraction of the reference agonist's: 0.6
Beside the measured number, compound 3's estimate is 0.30 below it; measured number inside the range.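

On this aromatic carbon, thiophen-2-yl in place of 2-hydroxyphenyl gives a number at least 0.30 higher from compound 2 to compound 3 (beyond the scatter) in this assay, and thiophen-2-yl in place of 4-methylphenyl gives a number at least 0.30 higher from compound 1 to compound 3 (beyond the scatter). So the group at this position can change the maximal response by more than the scatter, which the earlier pair could not show, as its own step cannot be read: the limit of < 0.3 in this assay, at which 2 of the 3 values shown sit.

From the compounds shown here alone, whether the rise follows the five-membered ring or its sulfur stays open. A furan-2-yl group, with oxygen where thiophene has sulfur, would bear on that question.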